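Swapping the pyridine of compound 2 for a thiazole

A few compounds are considered here, and "the series" means these few. Any claim that something is new, unique, unknown or untested is made for them only; others in the source may bear on it.

Values in a functional assay on A549 cells (Homo sapiens) for inhibition, read by MTT assay, with a stated time of 48 h; a lower number here means a stronger inhibitor, a higher number a weaker inhibitor:
Compound 1 `O=C(Nc1ccncc1)Nc1cc(-c2cccnc2)ccc1OC(F)(F)F`: 39800 nM
Compound 2 `COc1ccc(-c2ccc(OC(F)(F)F)c(NC(=O)Nc3ccncc3)c2)cn1`: > 300000 nM (a limit)

Between these two, the only measured step is an at least 7.5-fold higher number from compound 1 to compound 2 (0.87 log units; beyond the scatter), with methoxy in place of hydrogen on an aromatic carbon. Compound 2 therefore stands at the weak end of the pair, with no number of its own. Its entry, > 300000 nM, is a limit of this assay. This is recorded in the one note on the data: the limit of > 300000 nM in this assay, at which 1 of the 2 values shown sits.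

Compound 3 `COc1ccc(-c2ccc(OC(F)(F)F)c(NC(=O)Nc3nccs3)c2)cn1` keeps that methoxy and changes the other end of the molecule: 1,3-thiazol-2-yl in place of pyridin-4-yl on an amide-type nitrogen. In words, it has 1,3-thiazol-2-yl in place of pyridin-4-yl on an amide-type nitrogen. For the measured compounds named here, no measured step covers this swap, so the methoxy step bears on it only indirectly. Going by the values given here, compound 1, at 39800 nM, shows only that a measurable value is possible in this pair.

A move toward a lower number is expected, though a modest one, and it could still end at the limit. The expected step is an at least 3.0-fold lower number from compound 2 to compound 3 (0.47 log units; beyond the scatter). For compound 3 the estimated value is 100000 nM, with an expected range of 20000 nM to 300000 nM.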

Compound 3, half-maximal inhibitory concentration: 35000 nM
Compound 3: the middle estimate sits 2.9-fold (0.46 log units) above what was measured; measured number inside the range.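

In this assay the swap to 1,3-thiazol-2-yl on the amide-type nitrogen gives an at least 8.5-fold lower number from compound 2 to compound 3 (0.93 log units; beyond the scatter) and so shows that this position, untouched in the earlier pair, can bring a methoxy-bearing compound to a measured value. The earlier compounds shown here showed only a change at the other end of the molecule, whereas this step shows that, with the methoxy kept, a change of the group on this nitrogen is enough to move the value beyond the scatter. On these data alone, the full size of the step stays unknown, since compound 2 has a limit as its entry and not a number: the limit of > 300000 nM in this assay, at which 1 of the 3 values shown sits.

The compounds shown leave open whether this gain belongs to the thiazole as such or would also come with another ring on this nitrogen, such as 1,3-oxazol-2-yl or pyridin-2-yl, and whether a methyl group on the thiazole would carry it further. As far as these compounds go, it also remains open whether 1,3-thiazol-2-yl would give a step of similar size in the compound without the methoxy, the pair that would set the two changes side by side.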